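Working notes: from dimethylamino to methyl

This account rests on a few compounds, and the source may have more. Where it says the series, first, only, none or still open, it means among the compounds named here.

Measured in a functional assay on HSC-4 cells (Homo sapiens) for cytotoxicity, with a stated time of 24 h; a lower number here means that less compound is tolerated, a higher number that more compound is tolerated:
- compound 1 `O=C1/C(=C/c2ccccc2)CCC/C1=C\c1ccc([N+](=O)[O-])cc1` gives 9200 nM
- compound 2 `O=C1/C(=C/c2ccc(Cl)cc2)CCC/C1=C\c1ccc([N+](=O)[O-])cc1` gives 2700 nM
- compound 3 `CN(C)c1ccc(/C=C2\CCC/C(=C\c3ccc([N+](=O)[O-])cc3)C2=O)cc1` gives > 400000 nM, a limit and not a number

Compound 3 thus has only a limit on the numbers shown. Compound 4 `Cc1ccc(/C=C2\CCC/C(=C\c3ccc([N+](=O)[O-])cc3)C2=O)cc1` carries methyl in place of dimethylamino on an aromatic carbon. The two steps in which dimethylamino enters bear most directly, and both are large: an at least 43-fold higher number from compound 1 to compound 3 (1.63 log units; beyond the scatter) and an at least 140-fold higher number from compound 2 to compound 3 (2.17 log units; beyond the scatter). The remaining step is modest: a 3.4-fold lower number from compound 1 to compound 2 (0.53 log units; beyond the scatter). Removing dimethylamino is therefore expected to give a large step to a lower number in this assay, estimated as an at least 57-fold lower number from compound 3 to compound 4 (1.75 log units; beyond the scatter). The estimate for compound 4 is 7000 nM, with a range of 2000 nM to 30000 nM.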

Compound 4, half-maximal cytotoxic concentration: 13000 nM
For compound 4 the middle estimate is 1.9-fold (0.27 log units) below the measured one; measured number inside the range.
By their numbers in this assay, from the lowest: compound 2; then compounds 1 and 4 (each within the scatter of the next). At a limit, above all of these: compound 3.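

In this assay, the high number is tied to dimethylamino and not to any group at this place: methyl in its stead gives an at least 30-fold lower number from compound 3 to compound 4 (1.48 log units; beyond the scatter). Methyl in place of hydrogen gives a 1.4-fold higher number from compound 1 to compound 4 (0.15 log units; within the scatter), so the two are not separated here, whereas methyl in place of chloro gives a 4.8-fold higher number from compound 2 to compound 4 (0.68 log units; beyond the scatter). The value of compound 3 is a limit and not a number, so the first step is bounded on one side only: the limit of > 400000 nM in this assay, at which 1 of the 4 values shown sits.

The compounds shown leave open whether a primary amine or a methoxy group at this place would track dimethylamino or methyl.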